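Thiophene in Place of Pyrrole at the Hydrazone Carbon

This account rests on a few compounds, and the source may have more. Where it says the series, first, only, none or still open, it means among the compounds named here.

Going by the values given here, the measured compounds so far are these. Compound 1 is `CC1=CC[C@H](C(C)(C)NC(=S)N/N=C/c2ccccc2)CC1`; in a functional assay on NCI/ADR-RES cells (Homo sapiens) for inhibition, read by sulforhodamine B assay, with a stated time of 48 h (on this read-out higher numbers stand for weaker inhibition of growth and lower numbers for stronger inhibition of growth), compound 1 gives only the limit > 100000 nM. Compound 2 is `CC1=CC[C@H](C(C)(C)NC(=S)N/N=C/c2ccc(F)cc2)CC1`; in this assay compound 2 likewise gives only the limit > 100000 nM. Compound 3 is `CC1=CC[C@H](C(C)(C)NC(=S)N/N=C/c2ccc[nH]2)CC1`; in this assay compound 3 also gives only the limit > 100000 nM.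

Compound 3 thus stands where all three values sit, at the limit of > 100000 nM in this assay, at which 3 of the 3 values shown sit. Compound 4 is `CC1=CC[C@H](C(C)(C)NC(=S)N/N=C/c2cccs2)CC1`, and it differs from compound 3 in one place: thiophen-2-yl in place of 1H-pyrrol-2-yl on a carbon with a double bond to nitrogen.

Three measured steps surround this change. The step that the two limits leave unreadable from compound 1 to compound 2 and the step that the two limits leave unreadable from compound 1 to compound 3 both run between two limits, as does the step that the two limits leave unreadable from compound 2 to compound 3, so none of them has a readable size and none tells whether an aromatic exchange at this carbon moves the read-out at all. Among the compounds with values here, the same holds for the change to compound 4: the reachable values give no footing for a step of any size in this assay, and the expectation is therefore a result that again sits at the limit. Compound 4 is accordingly estimated at 100000 nM, within 30000 nM to 300000 nM, which would mean a step of a number no higher from compound 3 to compound 4 (the limit leaves the size open).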

Compound 4, concentration for total growth inhibition: 41000 nM
Beside the measured number, compound 4's estimate is 2.4-fold (0.39 log units) above it; the measured number falls inside the stated range.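

In this assay, going by these compounds alone, the exchange at the carbon with a double bond to nitrogen gives the first steps at this position with a readable lower bound: thiophen-2-yl in place of 1H-pyrrol-2-yl gives an at least 2.4-fold lower number from compound 3 to compound 4 (0.38 log units; beyond the scatter), in place of 4-fluorophenyl it gives an at least 2.4-fold lower number from compound 2 to compound 4 (0.38 log units; beyond the scatter), and in place of phenyl it gives an at least 2.4-fold lower number from compound 1 to compound 4 (0.38 log units; beyond the scatter). The steps among the three earlier compounds cannot be read, so only now is there evidence that an aromatic exchange at this carbon can move the read-out, and all three new steps give only a lower bound on their size. Compound 4 is the one compound of the four that returns a number rather than a limit, while the others remain at the limit: the limit of > 100000 nM in this assay, at which 3 of the 4 values shown sit.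

Going by these compounds, the true size of each step remains open, as does any order among compound 1, compound 2 and compound 3. Also open, on these data alone, is whether the gain belongs to thiophen-2-yl alone or extends to rings such as furan-2-yl or pyridin-2-yl, and whether a methyl group or a chlorine on the thiophene ring would lower the number further.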